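The source may hold more compounds than are shown below. What is called first, only, known or untested is meant among the compounds shown, and "the series" means these compounds.

Measured so far in a physicochemical assay for metabolic stability, read by HPLC; a lower number here means that the compound disappears faster, a higher number that the compound lasts longer:
- compound 1 `O=c1ccn([C@H]2CC[C@@H](COP(=O)(O)Oc3cccnc3)O2)c(=O)[nH]1`: 50.2 h
- compound 2 `O=c1ccn([C@H]2CC[C@@H](COP(=O)(O)Oc3ccccc3)O2)c(=O)[nH]1`: 25.1 h
- compound 3 `Cc1cn([C@H]2C[C@H](N=[N+]=[N-])[C@@H](COP(=O)(O)Oc3cccnc3)O2)c(=O)[nH]c1=O`: 3.88 h

Compound 3, at 3.88 h, holds the lowest of the three values, and its distance to each of the other two lies beyond the scatter. Compound 4 `Cc1ncccc1OP(=O)(O)OC[C@H]1O[C@@H](n2cc(C)c(=O)[nH]c2=O)C[C@@H]1N=[N+]=[N-]` differs from it at one place: methyl in place of hydrogen on an aromatic carbon. In short, methyl in place of hydrogen on an aromatic carbon, turning pyridin-3-yl into 2-methylpyridin-3-yl.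

Within the data shown here, no measured step adds a methyl. Among the measured compounds shown here, the only measured step that touches this aromatic group is a 2.0-fold lower number from compound 1 to compound 2 (0.30 log units; within the scatter), phenyl in place of pyridin-3-yl on an oxygen. It is a different change, made on a different core, so it is only a weak guide. On that basis, no step beyond the scatter is expected in this assay, and no direction can be firmly stated. The expected step is a 1.2-fold higher number from compound 3 to compound 4 (0.06 log units; within the scatter). The estimate for compound 4 is 4.5 h, with an expected range of 2 h to 10 h.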

Compound 4, half-life: 15.8 h
The estimate for compound 4 lay 3.5-fold (0.55 log units) below the measured number, and the stated range ends below it.
By their numbers in this assay, from the lowest: compound 3; then compounds 4, 2 and 1 (each within the scatter of the next, the first and the last beyond it).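

In this assay, among these compounds, methyl in place of hydrogen on an aromatic carbon gives a 4.1-fold higher number from compound 3 to compound 4 (0.61 log units; beyond the scatter) and is the first single change on this aromatic group to move the number beyond the scatter. The position is on the carbon next to the ring nitrogen and ortho to a large group, and the earlier change on this aromatic group, a 2.0-fold lower number from compound 1 to compound 2 (0.30 log units; within the scatter) on a different core, stayed within the scatter, so compound 4 is the only sign so far that this part of the molecule can matter in this assay. Nothing at hand speaks to the origin of this step.

As far as these compounds go, it remains open whether an ethyl, a methoxy or an amine at this place would give a step of the same direction and size. Also open, from the compounds shown here alone, is whether 2-methylpyridin-3-yl would shift the number on the core of compound 1 at 50.2 h as it does here.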